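A Nitrile on the Five-Membered Ring: Expecting Compound 4

A few compounds are considered here, and "the series" means these few. Any claim that something is new, unique, unknown or untested is made for them only; others in the source may bear on it.

Compound 1 `Cc1cnn(C(=O)NCc2ccc(OCc3ccccc3)cc2)c1`: 1200 nM
Compound 2 `Cc1cnn(C(=O)N2CCCN(Cc3ccc(OCc4ccccc4)cc3)CC2)c1`: 560 nM
Compound 3 `O=C(N1CCCN(Cc2ccc(OCc3ccccc3)cc2)CC1)n1cccn1`: 450 nM

These three values come from an assay on membranes from brain for binding affinity to Fatty-acid amide hydrolase 1 (Mus musculus), read by fluorescence, with stated times of 1 h and 30 min; a lower number here means a stronger inhibitor, a higher number a weaker inhibitor. Compound 3 has the lowest of the three numbers. Its nearest neighbour is compound 2, and the step of a 1.2-fold lower number from compound 2 to compound 3 (0.09 log units; within the scatter) lies within the scatter, so the two cannot be told apart. Among the measured compounds shown here, compound 1 gives 1200 nM, a number beyond the scatter above that of compound 3; the difference there is the carbamoyl-linked piperidine-type ring in place of the simple amide, a change for which no single step is drawn.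

Compound 4 `N#Cc1cnn(C(=O)N2CCCN(Cc3ccc(OCc4ccccc4)cc3)CC2)c1` differs from compound 3 by cyano in place of hydrogen on an aromatic carbon. For the measured compounds named here, no measured step bears directly on adding a nitrile. Going by the values given here, the only step on the same five-membered ring, a 1.2-fold lower number from compound 2 to compound 3 (0.09 log units; within the scatter), exchanged hydrogen for methyl and stayed within the scatter, which suggests that this ring tolerates small groups without a large shift. A modest change in either direction, or none beyond the scatter, is the most defensible expectation. Compound 4 is therefore estimated at 350 nM, with a range from 120 nM to 1000 nM. That corresponds to an expected step of a 1.3-fold lower number from compound 3 to compound 4 (0.11 log units; within the scatter).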

Compound 4, half-maximal inhibitory concentration: < 10 nM
Compound 4: a limit, no number; the forecaster's own chance of this, stated with the estimate: 5%; at least 35-fold (1.54 log units) between middle value and limit.
By their numbers in this assay, from the lowest: compounds 3 and 2 (each within the scatter of the next); then compound 1. At a limit, below all of these: compound 4.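

In this assay compound 4 gives < 10 nM, which is a limit of the assay and not a number. Hydrogen and methyl on this ring carbon could not be told apart, yet cyano in place of hydrogen gives an at least 45-fold lower number from compound 3 to compound 4 (1.65 log units; beyond the scatter), and cyano in place of methyl gives an at least 56-fold lower number from compound 2 to compound 4 (1.74 log units; beyond the scatter), so what this carbon carries can matter a great deal. Both steps are large and beyond the scatter, but their full size cannot be read from the data: the limit of < 10 nM in this assay, at which 1 of the 4 values shown sits.

On these data alone, whether this large shift is special to cyano, or would also come with a carboxylic acid, an amide or a chlorine atom on the same carbon, remains open. Also open, as far as these compounds go, is whether cyano would bring a similar shift on the core of compound 1.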